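Chloro removal on the sulfonyl aryl ring of compound 3

This account rests on a few compounds, and the source may have more. Where it says the series, first, only, none or still open, it means among the compounds named here.

Compound 3 `O=S(=O)(Nc1ccc(-c2nc3cc(NS(=O)(=O)c4ccc(Cl)s4)ccc3o2)cc1)c1ccc(Cl)c(C(F)(F)F)c1` gives 6100 nM in an assay for inhibition of HSP60/HSP10 (Homo sapiens), with a stated time of 60 min (a lower number here means a stronger inhibitor, a higher number a weaker inhibitor), the lowest of the three numbers. Compound 1 `O=S(=O)(Nc1ccc2oc(-c3ccc(NS(=O)(=O)c4cccc5nonc45)cc3)nc2c1)c1ccc(Cl)s1` gives 11000 nM, and the step of a 1.8-fold lower number from compound 1 to compound 3 (0.26 log units; within the scatter) is within the scatter. Compound 2 `O=S(=O)(Nc1ccc(-c2nc3cc(NS(=O)(=O)c4cccc(C(F)(F)F)c4)ccc3o2)cc1)c1cccc(C(F)(F)F)c1` gives 58000 nM, a number well beyond the scatter from compound 3. Compound 4 `O=S(=O)(Nc1ccc(-c2nc3cc(NS(=O)(=O)c4ccc(Cl)s4)ccc3o2)cc1)c1cccc(C(F)(F)F)c1` carries hydrogen in place of chloro on an aromatic carbon, that is, 4-chloro-3-(trifluoromethyl)phenyl becomes 3-(trifluoromethyl)phenyl. Among the measured compounds shown here, no measured step removes a chloro, so nothing bears on it directly; compound 2, which carries that same 3-(trifluoromethyl)phenyl group at both ends, only shows that this group can sit in a much weaker compound. A modest rise toward a higher number is expected, a 2.0-fold higher number from compound 3 to compound 4 (0.29 log units; within the scatter). Compound 4 is estimated at 12000 nM, within 4000 nM to 40000 nM.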

Compound 4, half-maximal inhibitory concentration: 4500 nM
Estimate against measurement, compound 4: 2.7-fold (0.43 log units) above, within the range that was stated.
By their numbers in this assay, from the lowest: compounds 4, 3 and 1 (each within the scatter of the next, the first and the last beyond it); then compound 2.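

In this assay, hydrogen in place of chloro on the 3-(trifluoromethyl)phenyl ring gives a 1.4-fold lower number from compound 3 to compound 4 (0.13 log units; within the scatter), so this chloro is not required for the activity seen here. With 5-chlorothiophen-2-yl kept, the same ring on the sulfonyl sulfur shows a 2.4-fold lower number from compound 1 to compound 4 (0.39 log units; beyond the scatter), while 5-chlorothiophen-2-yl in place of 3-(trifluoromethyl)phenyl at the other sulfonyl sulfur gives the far larger a 13-fold lower number from compound 2 to compound 4 (1.11 log units; beyond the scatter). Nothing available accounts for these steps. Going by these compounds, whether an amine or a carboxylic acid in place of the chloro would shift the number remains open. So does the contribution of the trifluoromethyl group itself.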